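The source may report more compounds than this note shows. Statements on the series, on what has been measured and on what is new or still open speak of the compounds shown alone.

Within the data shown here, in a functional assay on cells (Platelet, Homo sapiens) for inhibition (on this read-out lower numbers stand for stronger inhibition and higher numbers for weaker inhibition), only one true number is available so far. Compound 1 `CCOC(=O)c1ccc(-c2nn(Cc3ccc(OC)cc3)c3ccccc23)cc1` gives 620 nM. Compound 2 `CCOC(=O)c1cccc(-c2nn(Cc3ccccc3)c3ccccc23)c1` is recorded at > 10000 nM, and this is a limit of the assay, not a number. Among the measured compounds shown here, compound 1 is therefore the only compound with a measured value, and it is the reference for what follows. For the measured compounds named here, the two compounds differ in more than one place, and no measured step between compounds differing in one place exists to show how large a single change might be.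

Compound 3 `CCOC(=O)c1ccc(-c2nn(C(C)C)c3ccccc23)cc1` departs from compound 1 in one place: isopropyl in place of 4-methoxybenzyl on an aromatic nitrogen. An isopropyl group replaces the 4-methoxybenzyl group on the aromatic nitrogen, so the six-membered aromatic ring of that group is lost and no ring enters in its place. With so much of the group removed, weaker inhibition in this assay is expected for compound 3 than for compound 1 at 620 nM. The estimated step of a 5.6-fold higher number from compound 1 to compound 3 (0.75 log units; beyond the scatter) is expected to lie beyond the usual scatter, although its size remains uncertain. Compound 3 is estimated at 3500 nM, with an expected range of 1200 nM to 10000 nM.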

Compound 3, half-maximal inhibitory concentration: 650 nM
Compound 3: middle estimate off by 5.4-fold (0.73 log units), on the high side; the whole stated range lies above it.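

In this assay the exchange on the aromatic nitrogen comes to a 1.0-fold higher number from compound 1 to compound 3 (0.02 log units; within the scatter) and so leaves the two compounds indistinguishable on this read-out. The result shows that, in this pair, 4-methoxybenzyl with its 9 heavy atoms, its six-membered aromatic ring and its hydrogen-bond acceptor can give way to isopropyl with 3 heavy atoms and no ring, and the inhibition stays within the scatter. No information given here accounts for this outcome.

The compounds shown leave open whether a still smaller group on this nitrogen, such as methyl, or a longer chain such as n-hexyl, or an amine-bearing chain would also keep this inhibition. Also open, as far as these compounds go, is what the ethyl ester of the shared core contributes, a question that a carboxylic acid or an amide in its place would address.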